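A few compounds are considered here, and "the series" means these few. Any claim that something is new, unique, unknown or untested is made for them only; others in the source may bear on it.

Compound 1 `Nc1nccn2cc(-c3ccccc3)nc12` is the smallest member of this set. In an assay on cells for displacement of a labelled ligand from transmembrane domain-containing protein TMIGD3 (Homo sapiens), read by scintillation counting, with a stated time of 120 min, tested at 1 uM (a higher number here means more inhibition at the concentration tested (going by the name of the read-out), a lower number less inhibition), compound 1 gives 12%, the lowest of the three numbers measured. Compound 2 `O=C(Nc1nccn2cc(-c3ccccc3)nc12)c1ccco1` gives 40%, and compound 3 `O=C(Nc1nccn2cc(-c3ccccc3)nc12)c1cccnc1` gives 42%. Both measured steps start from compound 1: a number 28 percentage points higher from compound 1 to compound 2 (beyond the scatter), and a number 30 percentage points higher from compound 1 to compound 3 (beyond the scatter), while between the two acylated compounds a number 2 percentage points higher from compound 2 to compound 3 (within the scatter). Compound 4 `COc1ccc(-c2cn3cc(-c4ccccc4)nc3c(N)n2)cc1` has not yet been measured. It differs from compound 1 by 4-methoxyphenyl in place of hydrogen on an aromatic carbon, a change on an aromatic carbon of the shared core, while the amino group stays as in compound 1. Neither measured step touches that position; both alter the amino group instead, so they do not bear on this step, and the data give no guide to its size or direction. Compound 4 is therefore expected to give 25%, with a range from 5% to 55%. This corresponds to an expected step of a number 13 percentage points higher from compound 1 to compound 4 (beyond the scatter), which may well fall within the scatter.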

Compound 4, a percentage reported as inhibition, at one concentration (the size of the read-out at that concentration, not a potency): 23%
The estimate for compound 4 lay 2 percentage points above the measured number; measured number inside the range.
By their numbers in this assay, from the lowest: compound 1; then compound 4; then compounds 2 and 3 (each within the scatter of the next).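

Going by these compounds alone, compound 4 gives the first reading at this aromatic carbon, on the six-membered aromatic ring with 2 nitrogen, where the earlier compounds carried only hydrogen. With the amino group left free, 4-methoxyphenyl in place of that hydrogen gives, in this assay, a number 11 percentage points higher from compound 1 to compound 4 (beyond the scatter) as a modest step, so this position can change the number without any acyl group on the amino nitrogen. Nothing in the data accounts for this step.

Still open, from the compounds shown here alone, is whether a plain phenyl, a morpholine or a carboxylic acid at this aromatic carbon would give a different number, and whether the methoxy group contributes at all. Also open, going by these compounds, is whether 4-methoxyphenyl and an acylated amino group, such as (pyridin-3-yl)carbonyl, would add up on one core.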